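The source may hold more compounds than are shown below. What is called first, only, known or untested is meant among the compounds shown, and "the series" means these compounds.

In a functional assay on A549 cells (Homo sapiens) for inhibition, read by MTT assay, with a stated time of 48 h (on this read-out lower numbers stand for stronger inhibition and higher numbers for weaker inhibition), compound 1 `COc1ccc(N(C)c2nc(C)nc3ccccc23)cc1C(=O)OCCC[Se]C#N` gives 250 nM, the second highest of three numbers, with compound 2 `COc1ccc(N(C)c2nc(C)nc3ccccc23)cc1OCC[Se]C#N` at 13 nM and compound 3 `COc1ccc(N(C)c2nc(C)nc3ccccc23)cc1OCCCC[Se]C#N` at 1200 nM. Compound 4 `COc1ccc(N(C)c2nc(C)nc3ccccc23)cc1C(=O)OCCCCC[Se]C#N` differs from compound 1 by a group of 5 heavy atoms (3 carbon, 1 nitrogen, 1 selenium; no ring) in place of a group of 3 heavy atoms (1 carbon, 1 nitrogen, 1 selenium; no ring), on a saturated chain carbon, three bonds along the chain from an oxygen next to a carbonyl group. The most relevant measured step is a 92-fold higher number from compound 2 to compound 3 (1.97 log units; beyond the scatter), a large step for the same exchange of groups, there made two bonds along the chain from an oxygen on an aromatic ring. The steps of a 19-fold lower number from compound 1 to compound 2 (1.28 log units; beyond the scatter) and a 4.8-fold higher number from compound 1 to compound 3 (0.68 log units; beyond the scatter) bear on it less directly, as both exchange a whole group on an aromatic carbon. Among the measured compounds shown here, with only one precedent, the expected change is a 6.0-fold higher number from compound 1 to compound 4 (0.78 log units; beyond the scatter), in the same direction but smaller. For compound 4 the estimate is 1500 nM, with an expected range of 400 nM to 6000 nM.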

Compound 4, half-maximal inhibitory concentration: 592 nM
For compound 4 the middle estimate is 2.5-fold (0.40 log units) above the measured one; measured number inside the range.
By their numbers in this assay, from the lowest: compound 2; then compound 1; then compound 4; then compound 3.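

At this position, on a saturated chain carbon, three bonds along the chain from an oxygen next to a carbonyl group, the exchange of the smaller group for the larger gives a 2.4-fold higher number from compound 1 to compound 4 (0.37 log units; beyond the scatter). The direction matches the earlier precedent, but the size of the step depends on the core carrying it: the same change on two cores in this assay, a 92-fold higher number (1.97 log units; beyond the scatter) from compound 2 to compound 3 and a 2.4-fold higher number (0.37 log units; beyond the scatter) from compound 1 to compound 4, 39-fold (1.59 log units) apart, beyond the scatter of two such steps

The compounds shown leave open whether the smaller step belongs to the carbonyl link or to the length of the chain itself. On these data alone, how a longer chain or an amide link would read here also remains open.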